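The source may hold more compounds than are shown below. What is called first, only, known or untested is meant among the compounds shown, and "the series" means these compounds.

Measured in a functional assay on K562 cells (Homo sapiens), read by MTT assay, with a stated time of 72 h; a higher number here means a weaker inhibitor, a lower number a stronger inhibitor:
- compound 1 `CN(C)c1ncnc2c1c(-c1ccoc1)cn2[C@@H]1O[C@H](CO)[C@@H](O)[C@H]1O`: 14900 nM
- compound 2 `CN(C)c1ncnc2c1c(-c1ccsc1)cn2[C@@H]1O[C@H](CO)[C@@H](O)[C@H]1O`: > 20000 nM (a limit, not a number)

Compound 2 has no exact position in this assay, only (the limit of > 20000 nM in this assay, at which 1 of the 2 values shown sits).

Next comes compound 3 `C#Cc1cn([C@@H]2O[C@H](CO)[C@@H](O)[C@H]2O)c2ncnc(N(C)C)c12`, with ethynyl in place of thiophen-3-yl on an aromatic carbon.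

Among the measured compounds shown here, the only measured step that bears on this is an at least 1.3-fold higher number from compound 1 to compound 2 (0.12 log units; that floor lies within the scatter), thiophen-3-yl in place of furan-3-yl. It exchanges one ring for another and does not cover the loss of a ring, so it is only a weak guide. For the measured compounds named here, with compound 1 at 14900 nM as the sole number in this assay, a modest move toward a lower number is expected, with wide uncertainty. The expected change is an at least 2.8-fold lower number from compound 2 to compound 3 (0.45 log units; beyond the scatter), and this size is only an estimate. For compound 3 the estimated value is 7000 nM, with an expected range of 1000 nM to 20000 nM.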

Compound 3, half-maximal inhibitory concentration: 260 nM
Compound 3: middle estimate off by 27-fold (1.43 log units), on the high side, and the stated range ends above it.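

In this assay, this aromatic carbon, two ring bonds from the ring nitrogen, responds strongly to the group it carries, which compound 1 and compound 2, both with a five-membered aromatic ring there, did not show. Ethynyl in place of furan-3-yl gives a 57-fold lower number from compound 1 to compound 3 (1.76 log units; beyond the scatter), and ethynyl in place of thiophen-3-yl gives an at least 76-fold lower number from compound 2 to compound 3 (1.88 log units; beyond the scatter). The second step is only a floor, since compound 2 carries a limit and not a number: the limit of > 20000 nM in this assay, at which 1 of the 3 values shown sits.

The compounds shown do not separate the triple bond from the loss of the ring and its heavy atoms. An ethyl group or a longer alkyne chain on the same carbon would bear on which of these matters.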